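Carbonyl substituent exchange in three measured compounds

A few compounds are considered here, and "the series" means these few. Any claim that something is new, unique, unknown or untested is made for them only; others in the source may bear on it.

Compound 1 `Cc1nc(S(C)(=O)=O)ccc1Oc1ncnc(OC2CCN(C(=O)O[C@@H](C)C(F)(F)F)CC2)c1F` gives 80% in a functional assay on isolated protein for inhibition of Glucose-dependent insulinotropic receptor (Rattus norvegicus), read by HTRF and cAMP accumulation (on this read-out lower numbers stand for smaller maximal responses and higher numbers for larger maximal responses), the lowest of the three numbers, though both others lie within the scatter of it: compound 2 `Cc1nc(S(C)(=O)=O)ccc1Oc1ncnc(OC2CCN(C(=O)OC3(C(F)(F)F)COC3)CC2)c1F` gives 84% and compound 3 `Cc1nc(S(C)(=O)=O)ccc1Oc1ncnc(OC2CCN(C(=O)c3noc(C(C)C)n3)CC2)c1F` gives 81%. The steps of a number 4 percentage points higher from compound 1 to compound 2 (within the scatter), a number 1 percentage points higher from compound 1 to compound 3 (within the scatter) and a number 3 percentage points lower from compound 2 to compound 3 (within the scatter) all stay within the scatter. Compound 4 `Cc1nc(S(C)(=O)=O)ccc1Oc1ncnc(OC2CCN(C(=O)c3ncc(Cl)cn3)CC2)c1F` differs from compound 1 by 5-chloropyrimidin-2-yl in place of 1-(trifluoromethyl)ethoxy on a carbonyl carbon. The step of a number 1 percentage points higher from compound 1 to compound 3 (within the scatter) bears most directly on this change, since it likewise exchanges the 1-(trifluoromethyl)ethoxy group on the carbonyl carbon for an aromatic ring and stayed within the scatter. No step beyond the scatter is therefore expected in this assay. For compound 4 the estimate is 80%, with a range from 70% to 90%. The expected step is no change at the digits printed from compound 1 to compound 4 (within the scatter), within the scatter.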

Compound 4, largest response reached (reported as efficacy), in percent of the reference or control that the assay uses: 77%
Estimate against measurement, compound 4: 3 percentage points above; the measured number falls inside the stated range.
By their numbers in this assay, from the lowest: compounds 4, 1, 3 and 2 (each within the scatter of the next).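

At the carbonyl carbon, 5-chloropyrimidin-2-yl replaces the earlier groups with all three new steps in this assay inside the scatter (a number 3 percentage points lower from compound 1 to compound 4 (within the scatter); a number 4 percentage points lower from compound 3 to compound 4 (within the scatter); a number 7 percentage points lower from compound 2 to compound 4 (within the scatter)). Among these four compounds, this position therefore accepts a six-membered aromatic ring with 2 hetero atoms as well as the two ether-linked groups and the 5-isopropyl-1,2,4-oxadiazol-3-yl group, and no step exceeds the scatter. No measurement at hand accounts for this result.

As far as these compounds go, how an amine or a longer chain ending in a carboxylic acid on this carbonyl carbon would read in this assay remains open.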